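Aryl Triazole Esters of a Terpenoid Core on Lung Cells

This account rests on a few compounds, and the source may have more. Where it says the series, first, only, none or still open, it means among the compounds named here.

Compound 1 `C/C(=C\CC/C(C)=C/CC[C@@H]1[C@@]2(C)CCC(=O)C(C)(C)[C@H]2CC[C@@]1(C)O)CC/C=C(\C)C(=O)OCc1cn(-c2ccccc2C(F)(F)F)nn1` gives in an ADME assay on L132 cells (Homo sapiens) for cytotoxicity, read by MTT assay, with a stated time of 48 h (on this read-out higher numbers stand for weaker inhibition and lower numbers for stronger inhibition), a limit, not a number: > 150000 nM.
Compound 2 `C/C(=C\CC/C(C)=C/CC[C@@H]1[C@@]2(C)CCC(=O)C(C)(C)[C@H]2CC[C@@]1(C)O)CC/C=C(\C)C(=O)OCc1cn(-c2ccccc2Br)nn1` gives in this assay likewise a limit and not a number: > 150000 nM.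
Compound 3 `C/C(=C\CC/C(C)=C/CC[C@@H]1[C@@]2(C)CCC(=O)C(C)(C)[C@H]2CC[C@@]1(C)O)CC/C=C(\C)C(=O)OCc1cn([C@@H]2C[C@@H](n3cc(C)c(=O)[nH]c3=O)O[C@H]2CO)nn1` gives in this assay a number, 115000 nM.

Compound 2 therefore stands at the edge of what this assay can report, and its reading is a limit only. For the measured compounds named here, compound 3 is the one compound of the three with a number, and that number lies close to the edge as well. The pattern across the set is summed up by the limit of > 150000 nM in this assay, at which 2 of the 3 values shown sit.

Compound 4 `C/C(=C\CC/C(C)=C/CC[C@@H]1[C@@]2(C)CCC(=O)C(C)(C)[C@H]2CC[C@@]1(C)O)CC/C=C(\C)C(=O)OCc1cn(-c2ccc(Cl)cc2)nn1` differs from compound 2 in a single place: 4-chlorophenyl in place of 2-bromophenyl on an aromatic nitrogen. Going by the values given here, the only measured step between two compounds that differ in one place is a step that the two limits leave unreadable from compound 1 to compound 2. Both of its ends are limits, so its size cannot be read. Among the compounds with values here, no measured step therefore bears on a change of the phenyl substitution pattern in a readable way.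

Given that compounds 1 and 2 both sit at the limit and compound 3 sits near it, the expected step that the limit leaves unreadable from compound 2 to compound 4 is one of no readable size beyond the scatter, with the most likely outcome being another limit. Compound 4 is estimated at 160000 nM, within a range from 80000 nM to 320000 nM.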

Compound 4, half-maximal inhibitory concentration: > 150000 nM
Compound 4 was reported as a limit (the forecaster's own chance of this, stated with the estimate: 60%); the middle value does not contradict the limit.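

In this assay compound 4 gives > 150000 nM as a limit and not a number. Its steps from compound 1 and from compound 2 therefore join limit to limit, and neither can be read. From the compounds shown here alone, how far these three compounds lie from the limit, and whether 4-chlorophenyl in place of 2-bromophenyl changes the read-out at all, remains open.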